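The source may hold more compounds than are shown below. What is called first, only, known or untested is meant among the compounds shown, and "the series" means these compounds.

Measured compounds in an ADME assay on LLC-MK2 cells (Macaca mulatta) for cytotoxicity, read by spectrophotometry and crystal violet staining, with a stated time of 4 days; a higher number here means that more compound is tolerated, a lower number that less compound is tolerated:
- compound 1 `CC(C)n1ncc2c(C(=O)Nc3ccccn3)cc(-c3ccsc3)nc21` gives 25000 nM
- compound 2 `CC(C)n1ncc2c(C(=O)Nc3ccc(F)cc3)cc(-c3ccco3)nc21` gives > 200000 nM
- compound 3 `CC(C)n1ncc2c(C(=O)Nc3cccc(F)c3F)cc(-c3cccs3)nc21` gives 75000 nM

Compound 2 stands apart from the other two: its value in this assay is only a limit, > 200000 nM, and no number is known for it. Going by the values given here, it is the one of the three values that sits at the limit of > 200000 nM in this assay, at which 1 of the 3 values shown sits. Compound 1 and compound 3 each give a number, and of these two compound 1 is the lower.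

The step from compound 2 to compound 4 `CC(C)n1ncc2c(C(=O)Nc3ccc(F)cc3)cc(-c3ccsc3)nc21` changes one place on the shared core: thiophen-3-yl in place of furan-2-yl on an aromatic carbon. Nothing else moves, and the 4-fluorophenyl amide is kept. Among the compounds with values here, no measured pair in this set isolates the same change, so the direction of the step is not fixed by the data. Within the data shown here, compound 1, which also carries thiophen-3-yl, and compound 3, which carries a thiophene as well, both give numbers rather than limits, while the only furan-2-yl compound gives a limit. On that basis the step is expected to move compound 4 towards a measurable value rather than to stay at the limit, but the size is uncertain and could be within the scatter.

Compound 4 is expected to give about 100000 nM in this assay, with a range from 30000 nM to 250000 nM, the step of an at least 2.0-fold lower number from compound 2 to compound 4 (0.30 log units; that floor lies within the scatter) being the estimated change.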

Compound 4, half-maximal cytotoxic concentration: > 200000 nM
Compound 4 was reported as a limit (the forecaster's own chance of this, stated with the estimate: 35%); at least 2.0-fold (0.30 log units) between middle value and limit.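

In this assay, thiophen-3-yl in place of furan-2-yl on the aromatic carbon next to the ring nitrogen leaves compound 4 at a limit, as compound 2 is, so that step cannot be read in size or direction. Thiophen-3-yl at this position therefore does not by itself bring the value down to a measurable number. With thiophen-3-yl held constant, 4-fluorophenyl in place of pyridin-2-yl on the amide-type nitrogen gives an at least 8.0-fold higher number from compound 1 to compound 4 (0.90 log units; beyond the scatter), so the one readable step among the compounds shown lies at the amide, and the number of compounds at the limit has grown: the limit of > 200000 nM in this assay, at which 2 of the 4 values shown sit.

On these data alone, how far compound 2 and compound 4 actually lie from each other stays open, as does whether furan-2-yl and thiophen-3-yl would differ at all with pyridin-2-yl on the amide. The compounds shown also give no reading of how an amine or a carboxylic acid on that same aromatic carbon would change the tolerated concentration in this assay.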